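A few compounds are considered here, and "the series" means these few. Any claim that something is new, unique, unknown or untested is made for them only; others in the source may bear on it.

Compound 3 `O=C1OCCN1C(=O)c1ccc(OC2CCCC2)cc1` holds the lowest number of the three measured in an assay on HEK293 cells for inhibition of N-acylethanolamine-hydrolyzing acid amidase (Rattus norvegicus), read by LC-MS, with a stated time of 30 min; a lower number here means a stronger inhibitor, a higher number a weaker inhibitor; in this assay compound 3 gives 120 nM. Compound 1 `O=C1OCCN1C(=O)c1ccc(Oc2ccccc2)cc1` is the nearest to it, and in this assay compound 1 gives 680 nM. Compound 2 `Cc1cccc(Oc2ccc(C(=O)N3CCOC3=O)cc2)c1` is the furthest, and in this assay compound 2 gives 5210 nM. The two steps that arrive at compound 3 both exchange an aromatic ring on the oxygen for cyclopentyl: a 5.7-fold lower number from compound 1 to compound 3 (0.75 log units; beyond the scatter) and a 43-fold lower number from compound 2 to compound 3 (1.64 log units; beyond the scatter). Within the aromatic pair, a 7.7-fold higher number from compound 1 to compound 2 (0.88 log units; beyond the scatter).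

Compound 4 `CCCCCCOc1ccc(C(=O)N2CCOC2=O)cc1` takes the next step from compound 3: hexyl in place of cyclopentyl on an oxygen on an aromatic ring. Neither measured step bears on it directly. The steps to compound 3 show only that cyclopentyl on this oxygen gives a lower number than either aromatic ring; nothing measured here compares a ring on the oxygen with a chain, and the hexyl chain has no ring at all. For the measured compounds named here, with no precedent for a chain, the expected step is held close to no change, allowing room in either direction: a 1.8-fold higher number from compound 3 to compound 4 (0.26 log units; within the scatter). For compound 4 the estimate in this assay is 220 nM, with an expected range from 60 nM to 800 nM.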

Compound 4, half-maximal inhibitory concentration: 640 nM
Estimate against measurement, compound 4: 2.9-fold (0.46 log units) below; the measured number falls inside the stated range.
By their numbers in this assay, from the lowest: compound 3; then compounds 4 and 1 (each within the scatter of the next); then compound 2.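

The hexyl result brings a chain into the comparison at this oxygen on an aromatic ring: in this assay there is a 5.3-fold higher number from compound 3 to compound 4 (0.73 log units; beyond the scatter), so the lower number of cyclopentyl now holds against a chain as well as against both aromatic rings. A ring on this oxygen does not decide the number by itself, since ringless hexyl cannot be separated from phenyl, with a 1.1-fold lower number from compound 1 to compound 4 (0.03 log units; within the scatter), while there is an 8.1-fold lower number from compound 2 to compound 4 (0.91 log units; beyond the scatter) and 3-methylphenyl remains apart from the other three groups on the high side. No measurement available here accounts for these differences.

Still open, as far as these compounds go, is how the number follows chain length at this oxygen, with butyl and octyl as the obvious neighbours of hexyl, and whether a branched chain such as isopentyl falls nearer to hexyl or to cyclopentyl. Also open, from the compounds shown here alone, is how far the result for cyclopentyl extends to other saturated rings such as cyclobutyl or cyclohexyl, and what an amine or a carboxylic acid at the end of the hexyl chain would do to the number.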